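Compound 2 and a methylcarbamoyl swap

This account rests on a few compounds, and the source may have more. Where it says the series, first, only, none or still open, it means among the compounds named here.

Measured in a functional assay (mast cells) for inhibition, with Rattus norvegicus as the target; on this read-out higher numbers stand for an effect only at larger amounts of compound and lower numbers for an effect already at smaller amounts:
Compound 1 (`CC1CC/C(=N\Nc2ccc(C(F)(F)F)cc2)c2ncc(C(=O)O)c(=O)n21`): 280 nM
Compound 2 (`CC1CC/C(=N\Nc2ccc(CC(=O)O)cc2)c2ncc(C(=O)O)c(=O)n21`): 3400 nM
Not yet measured: compound 3 (`CNC(=O)c1ccc(N/N=C2\CCC(C)n3c2ncc(C(=O)O)c3=O)cc1`)

Compound 2, at 3400 nM, holds the higher of the two numbers in this assay. Compound 3 differs from it in one place: methylcarbamoyl in place of carboxymethyl on an aromatic carbon. Methylcarbamoyl takes the place of carboxymethyl on an aromatic carbon, para to a large group.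

Among the compounds with values here, one measured step bears on this place: a 12-fold higher number from compound 1 to compound 2 (1.08 log units; beyond the scatter). That step is large and beyond the scatter, and it arose when carboxymethyl replaced trifluoromethyl. It shows that a change here can move the number substantially, at least for this pair. Within the data shown here, no measured compound carries methylcarbamoyl, so the data do not show where that group falls. Among the measured compounds shown here, the only other group measured here, in compound 1 at 280 nM, gave a lower number than carboxymethyl. A moderate move towards a lower number is therefore expected, smaller than the measured step, and a result within the scatter cannot be excluded. The expected change is a 3.4-fold lower number from compound 2 to compound 3 (0.53 log units; beyond the scatter). In this assay, compound 3 is estimated at 1000 nM, with an expected range from 250 nM to 4000 nM.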

Compound 3, half-maximal effective concentration: 100000 nM
For compound 3 the middle estimate is 100-fold (2.00 log units) below the measured one; measured number above the stated range.
By their numbers in this assay, from the lowest: compound 1; then compound 2; then compound 3.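

Replacing carboxymethyl with methylcarbamoyl in this assay gives a 29-fold higher number from compound 2 to compound 3 (1.47 log units; beyond the scatter), even though the two groups have the same counts of heavy atoms, hydrogen-bond donors and hydrogen-bond acceptors, and differ in composition by a nitrogen in place of an oxygen. This position therefore responds strongly to a change that leaves those counts untouched, which the earlier trifluoromethyl to carboxymethyl step could not show. Within the data shown here, the span at this position also widens, with a 360-fold higher number from compound 1 to compound 3 (2.55 log units; beyond the scatter) as the largest step among the three compounds, and methylcarbamoyl now gives the highest number, but nothing available explains why this swap moves the number so far.

The compounds shown leave open how a plain carbamoyl, a dimethylcarbamoyl or a carboxylic acid set directly on the aromatic carbon would fall, and so whether the amide hydrogen or the methyl of methylcarbamoyl has any bearing on the result. Among these compounds, with only three groups at this one position on a single core, they also leave open whether the same order would hold elsewhere.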